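The compounds below may be only part of what the source reports. "The series", "measured", "known", "first", "only" and "open" are said of these compounds alone.

Going by the values given here, in a toxicity assay on NIH3T3 cells (Mus musculus) for cytotoxicity, read by resazurin assay (a lower number here means that less compound is needed, a higher number that more compound is needed for the effect), compound 1 (`c1ccc(-c2ccc(Cn3cncc3CNc3cccc(-c4ccccc4)c3)cc2)cc1`) gives 10000 nM as the only readable number. Compound 2 (`c1ccc(-c2ccc(Cn3cncc3CNc3ccc(-c4ccccc4)c(-c4ccccc4)c3)cc2)cc1`) reads > 10000 nM and that is a limit. Compound 3 (`CCC(=O)c1ccc(NCc2cncn2Cc2ccc(-c3ccccc3)cc2)cc1-c1ccccc1`) reads > 10000 nM and that too is a limit, which places it at the limit of > 10000 nM in this assay, at which 2 of the 3 values shown sit, without an exact number.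

Compound 4 (`O=C(OC1CCCCC1)c1ccc(NCc2cncn2Cc2ccc(-c3ccccc3)cc2)cc1-c1ccccc1`) follows from compound 3 through cyclohexyloxy in place of ethyl on a carbonyl carbon with cyclohexyloxy in place of ethyl on a carbonyl carbon. The measured steps that bear on this change are a number no lower from compound 1 to compound 3 (the limit leaves the size open) and a step that the two limits leave unreadable from compound 2 to compound 3 and also a number no lower from compound 1 to compound 2 (the limit leaves the size open) and none of them has a readable size.

Going by compound 3 and the open step a number no lower from compound 1 to compound 3 (the limit leaves the size open) in particular, no step beyond the scatter is expected in this assay and a reported limit is the likeliest outcome. The expected change is a step that the limit leaves unreadable from compound 3 to compound 4 on this reading. Compound 4 is estimated at 12000 nM with an expected range from 4000 nM to 30000 nM as a working figure.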

Compound 4, half-maximal effective concentration: > 10000 nM
Compound 4: no number, only a limit; the forecaster's own chance of this, stated with the estimate: 65%; the middle value lies beyond the limit too.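

In this assay compound 4 gives only a limit, > 10000 nM. Exchanging ethyl for cyclohexyloxy on the carbonyl carbon, which brings in a six-membered non-aromatic ring and a hydrogen-bond acceptor, does not move the series off its reported ceiling: the limit of > 10000 nM in this assay, at which 3 of the 4 values shown sit. Cyclohexyloxycarbonyl on the aromatic carbon gives a number no lower from compound 1 to compound 4 (the limit leaves the size open), while the steps linking compound 4 to compound 2 and compound 3 cannot be read.

The true size of every step among these limits remains open, so no ranking of compound 2, compound 3 and compound 4 can be drawn. Also open, as far as these compounds go, is whether an amine or a hydroxy group in place of cyclohexyloxy on the carbonyl carbon would give a readable number in this assay.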